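This account rests on a few compounds, and the source may have more. Where it says the series, first, only, none or still open, it means among the compounds named here.

In a functional assay on CCRF-CEM cells (Homo sapiens) for antiproliferative activity, with a stated time of 72 h (on this read-out lower numbers stand for stronger inhibition and higher numbers for weaker inhibition), two compounds sharing one core have been measured so far. Compound 1 (`COc1ccccc1CNc1ncnc2c1ncn2[C@@H]1O[C@H](CO)[C@@H](O)[C@H]1O`) gives 3200 nM, and compound 2 (`OC[C@H]1O[C@@H](n2cnc3c(NCc4ccc(F)c(F)c4F)ncnc32)[C@H](O)[C@@H]1O`) gives 58200 nM, the higher of the two numbers and so the weaker result. Compound 3 (`Cc1cccc(CNc2ncnc3c2ncn3[C@@H]2O[C@H](CO)[C@@H](O)[C@H]2O)c1O`) keeps the core and differs from compound 2 on a saturated chain carbon bound to a nitrogen on an aromatic ring, where 2-hydroxy-3-methylphenyl stands in place of 2,3,4-trifluorophenyl: 2-hydroxy-3-methylphenyl in place of 2,3,4-trifluorophenyl on a saturated chain carbon bound to a nitrogen on an aromatic ring. Going by the values given here, one measured step bears on this change: an 18-fold higher number from compound 1 to compound 2 (1.26 log units; beyond the scatter). That step is large and beyond the scatter, and it brought in the same 2,3,4-trifluorophenyl that compound 3 gives up. The entering group carries no fluorine and, like the 2-methoxyphenyl of compound 1, has an oxygen in its name, so much of that step may be expected to reverse, though a single step is thin support. A large move toward a lower number is therefore expected in this assay, with the estimated step being a 9.7-fold lower number from compound 2 to compound 3 (0.99 log units; beyond the scatter). For compound 3, the estimated value is 6000 nM, with an expected range of 1500 nM to 24000 nM.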

Compound 3, half-maximal inhibitory concentration: 900 nM
For compound 3 the middle estimate is 6.7-fold (0.82 log units) above the measured one; the whole stated range lies above it.
By their numbers in this assay, from the lowest: compound 3; then compound 1; then compound 2.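

In this assay, the step of a 65-fold lower number from compound 2 to compound 3 (1.81 log units; beyond the scatter) shows that the loss seen with 2,3,4-trifluorophenyl on this saturated chain carbon bound to a nitrogen on an aromatic ring can be fully recovered. The change does more than restore the level of compound 1, since 2-hydroxy-3-methylphenyl also goes past 2-methoxyphenyl, with a 3.6-fold lower number from compound 1 to compound 3 (0.55 log units; beyond the scatter), a modest step but beyond the scatter. Among these three compounds, both groups with an oxygen give lower numbers than the fluorine-bearing group of compound 2, and none goes against this, though no evidence is available here to account for the difference.

From the compounds shown here alone, what remains open is which part of 2-hydroxy-3-methylphenyl carries the gain over 2-methoxyphenyl, as the hydroxy and the methyl enter together in compound 3, and a phenyl bearing only one of them would separate the two. Going by these compounds, it is also open whether the trend extends to other groups on the ring, such as an amine or a carboxylic acid in place of the hydroxy.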